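A few compounds are considered here, and "the series" means these few. Any claim that something is new, unique, unknown or untested is made for them only; others in the source may bear on it.

Compound 3, `Cc1nc(NCC(C)C)nc(N[C@@H]2C[C@H](CO)[C@@H](O)[C@H]2O)c1-c1nc2ccccc2s1`, is one of three compounds for which a number is already in hand in an ADME assay on cells (Homo sapiens) for cytotoxicity, read by polymerase chain reaction, with a stated time of 3 days; on this read-out lower numbers stand for higher toxicity in this test and higher numbers for lower toxicity in this test. In this assay compound 3 gives 10000 nM. Its nearest neighbour is compound 1, `Nc1nc(Cl)c(-c2nc3ccc(Cl)cc3s2)c(N[C@@H]2C[C@H](CO)[C@@H](O)[C@H]2O)n1`, which in this assay gives 16000 nM; the two values lie within the usual scatter of each other, so neither can be called more or less toxic than the other. Compound 2, `COc1ccc2nc(-c3c(Cl)nc(N)nc3N[C@@H]3C[C@H](CO)[C@@H](O)[C@H]3O)sc2c1`, gives in this assay only a limit of > 25000 nM, not a number.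

Compound 4, `Cc1nc(NCCC(F)(F)F)nc(N[C@@H]2C[C@H](CO)[C@@H](O)[C@H]2O)c1-c1nc2ccccc2s1`, is not yet measured. It differs from compound 3 in one place: 2,2,2-trifluoroethyl in place of isopropyl on a saturated chain carbon bound to a nitrogen on an aromatic ring.

Within the data shown here, the only measured step between two compounds that differ in a single place is the one from compound 1 to compound 2, an at least 1.5-fold higher number from compound 1 to compound 2 (0.19 log units; that floor lies within the scatter), a change of methoxy in place of chloro on an aromatic carbon; compound 2 sits at the limit described as the limit of > 25000 nM in this assay, at which 1 of the 3 values shown sits. That step touches a different part of the molecules and does not bear on a change on a saturated chain carbon bound to a nitrogen on an aromatic ring. Among the measured compounds shown here, no measured step therefore speaks to the change from compound 3 to compound 4, and no step beyond the scatter is expected.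

Compound 4 is accordingly estimated at 10000 nM, within a range from 4000 nM to 25000 nM, which means an expected step of no change at the digits printed from compound 3 to compound 4 (within the scatter).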

Compound 4, half-maximal cytotoxic concentration: 9000 nM
Beside the measured number, compound 4's estimate is 1.1-fold (0.05 log units) above it, within the range that was stated.
By their numbers in this assay, from the lowest: compounds 4, 3 and 1 (each within the scatter of the next). At a limit, above all of these: compound 2.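

In this assay, among these compounds, this is the first reading at this place, on a saturated chain carbon bound to a nitrogen on an aromatic ring: putting 2,2,2-trifluoroethyl in place of isopropyl gives a 1.1-fold lower number from compound 3 to compound 4 (0.05 log units; within the scatter), so the two compounds cannot be told apart in this test. Among the compounds shown here, the earlier compounds could not show this, since their one step, methoxy in place of chloro on an aromatic carbon, lies in a different part of the molecules. Within this pair, then, bringing fluorine into the side chain leaves the cytotoxicity reading where the scatter cannot separate it, and nothing measured here offers a reason for that outcome.

Only this one swap has been seen at this place, so the compounds shown leave open whether an amine, a carboxylic acid, a longer chain or a cyclopropyl group there would give a step beyond the scatter. They also leave open whether the same swap would read alike on the core of compound 1, which carries an amino group and a chloro group instead.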